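The source may hold more compounds than are shown below. What is called first, only, known or untested is meant among the compounds shown, and "the series" means these compounds.

Compound 1 `COCC(C)Oc1cccc2ccc(N)nc12`: 606 nM
Compound 2 `Nc1ccc2cccc(OCCC3CCCCC3)c2n1`: 808 nM
Compound 3 `CCCCOc1cccc2ccc(N)nc12`: 789 nM

In an assay on cells with melanin-concentrating hormone receptor 1 (Homo sapiens) as the target, read by radioligand binding (on this read-out higher numbers stand for weaker inhibition and lower numbers for stronger inhibition), compound 3 gives 789 nM, the second highest of the three numbers; compound 2 is nearest and compound 1 furthest, both within the scatter. Compound 4 `CC(C)(C)CCOc1cccc2ccc(N)nc12` differs from compound 3 by tert-butyl in place of ethyl on a saturated chain carbon, two bonds along the chain from an oxygen on an aromatic ring. For the measured compounds named here, two measured steps bear on this: a 1.0-fold lower number from compound 2 to compound 3 (0.01 log units; within the scatter) swapped a group at the same place on the chain, and a 1.3-fold higher number from compound 1 to compound 3 (0.11 log units; within the scatter) changed the whole side chain, and both stayed within the scatter. A tert-butyl in place of ethyl is therefore expected to move this assay little. Compound 4 is estimated at 800 nM (range 350 nM to 1800 nM), an expected step of a 1.0-fold higher number from compound 3 to compound 4 (0.01 log units; within the scatter) within the scatter.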

Compound 4, half-maximal inhibitory concentration: 201 nM
Compound 4: middle estimate off by 4.0-fold (0.60 log units), on the high side; measured number below the stated range.
By their numbers in this assay, from the lowest: compound 4; then compounds 1, 3 and 2 (each within the scatter of the next).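

Unlike the earlier swaps on this chain, which all stayed within the scatter, tert-butyl in place of ethyl on this saturated chain carbon gives stronger inhibition (a 3.9-fold lower number from compound 3 to compound 4 (0.59 log units; beyond the scatter)). The 3,3-dimethylbutyl side chain also beats the cyclohexyl version (a 4.0-fold lower number from compound 2 to compound 4 (0.60 log units; beyond the scatter)) and the 1-(methoxymethyl)ethyl one (a 3.0-fold lower number from compound 1 to compound 4 (0.48 log units; beyond the scatter)), so this position does respond to the group placed on it. No measured evidence accounts for this gain. Still open, as far as these compounds go, is whether an isopropyl, a trifluoromethyl or an amine at this place would do as well.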